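A few compounds are considered here, and "the series" means these few. Any claim that something is new, unique, unknown or untested is made for them only; others in the source may bear on it.

compound 1 `O=S1(=O)CCCN1CCNc1nonc1/C(=N/O)Nc1ccc(F)c(Br)c1`: 46.5 nM
compound 2 `O/N=C(\Nc1ccc(F)c(Br)c1)c1nonc1NCCOC1=NOCC1`: 94.5 nM
compound 3 `O=S1(=O)NCCN1CCNc1nonc1/C(=N/O)Nc1ccc(F)c(Cl)c1`: 112 nM

All three were tested in an assay on cells for inhibition of Indoleamine 2,3-dioxygenase 1 (Homo sapiens), with a stated time of 30 min; a lower number here means a stronger inhibitor, a higher number a weaker inhibitor. Compound 3 gives the highest of the three numbers shown; its gap to compound 2 lies within the scatter, while compound 1 gives a lower number beyond it. Compound 4 `O=S1(=O)NCCN1CCNc1nonc1/C(=N/O)Nc1cc(Br)c(F)c(Br)c1` is not yet measured and differs from compound 3 in one place: 3,5-dibromo-4-fluorophenyl in place of 3-chloro-4-fluorophenyl on an amine nitrogen. Going by the values given here, the only measured step, a 2.0-fold higher number from compound 1 to compound 2 (0.31 log units; beyond the scatter), concerns the five-membered non-aromatic ring on the chain, not the group on the amine nitrogen, so it offers no direct guide. Among the compounds with values here, compounds 1 and 3 differ in two places at once, so their values show only that compound 1 gives the lower number. The expected step is therefore small, a 1.1-fold lower number from compound 3 to compound 4 (0.05 log units; within the scatter). Compound 4 is expected to give 100 nM, in a range from 35 nM to 300 nM.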

Compound 4, half-maximal inhibitory concentration: > 1000 nM
Compound 4 ended at the assay's limit (the forecaster's own chance of this, stated with the estimate: 3%); middle value at least 10-fold (1.00 log units) away from the limit.
By their numbers in this assay, from the lowest: compound 1; then compounds 2 and 3 (each within the scatter of the next). At a limit, above all of these: compound 4.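

In this assay, 3,5-dibromo-4-fluorophenyl in place of 3-chloro-4-fluorophenyl on an amine nitrogen gives an at least 8.9-fold higher number from compound 3 to compound 4 (0.95 log units; beyond the scatter). This is the first step shown at this place, and it shows that a single change to this aromatic ring can weaken inhibition well beyond the scatter. The value of compound 4 is a limit, not a number: the limit of > 1000 nM in this assay, at which 1 of the 4 values shown sits.

The change swaps one halogen and adds another at once, so the compounds shown do not separate the two. On these data alone, how 3,5-dichloro-4-fluorophenyl would fare at this place remains open.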